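A few compounds are considered here, and "the series" means these few. Any claim that something is new, unique, unknown or untested is made for them only; others in the source may bear on it.

Compound 2, `CC(=O)N1CCC(NC(=O)c2ccncc2Nc2cc(-c3ccc4ccn(C)c4c3)c3nccnc3c2)CC1`, is the stronger of the two compounds measured in an assay for inhibition of 6-phosphofructo-2-kinase/fructose-2,6-bisphosphatase 3 (Homo sapiens), read by ADP-Glo, with a stated time of 2 h; a lower number here means a stronger inhibitor, a higher number a weaker inhibitor: compound 2 gives 18 nM, while compound 1, `Cn1cc(CNC(=O)c2ccncc2Nc2cc(-c3ccc4ccn(C)c4c3)c3nccnc3c2)cn1`, gives 159 nM. Among the measured compounds shown here, the only measured step, an 8.8-fold lower number from compound 1 to compound 2 (0.95 log units; beyond the scatter), concerns the substituent on the amide-type nitrogen, and it shows that this position moves the numbers well beyond the scatter.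

Compound 3, `Cn1ccc2ccc(-c3cc(Nc4cnccc4C(=O)NC4CCNC(=O)C4)cc4nccnc34)cc21`, has not been measured. It differs from compound 2 in that same position: 2-oxopiperidin-4-yl in place of 1-acetylpiperidin-4-yl on an amide-type nitrogen. For the measured compounds named here, no measured pair shows this particular exchange, so the step from compound 1 to compound 2 bears on it only in that it marks the amide-type nitrogen substituent as a place where the read-out changes. Both compound 2 and compound 3 keep a six-membered non-aromatic ring with one hetero atom there, so a step as large as that from compound 1 to compound 2 is not expected; a modest weakening, or no change beyond the scatter, seems more likely. Compound 3 is therefore expected to give about 30 nM in this assay, within 10 nM to 90 nM, a step of a 1.7-fold higher number from compound 2 to compound 3 (0.22 log units; within the scatter).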

Compound 3, half-maximal inhibitory concentration: 69 nM
Compound 3: the middle estimate sits 2.3-fold (0.36 log units) below what was measured; measured number inside the range.
By their numbers in this assay, from the lowest: compound 2; then compound 3; then compound 1.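

In this assay, putting 2-oxopiperidin-4-yl in place of 1-acetylpiperidin-4-yl on the amide-type nitrogen gives a 3.8-fold higher number from compound 2 to compound 3 (0.58 log units; beyond the scatter) and so shows that the number at this position is not held by keeping one six-membered non-aromatic ring with 1 hetero atom there. Putting 2-oxopiperidin-4-yl in place of (1-methyl-1H-pyrazol-4-yl)methyl gives a 2.3-fold lower number from compound 1 to compound 3 (0.36 log units; beyond the scatter) and places the new group between the two earlier ones, so that this position now orders three substituents, with every step beyond the scatter. No measurement shown here accounts for this order, and the difference in hydrogen-bond donors between the two ring groups remains only a count.

The compounds shown leave open how a piperidin-4-yl with a free ring amine, a tetrahydropyran-4-yl ring or a 1-propanoylpiperidin-4-yl group would fall in this order, and therefore which part of the acetyl or ring carbonyl arrangement goes with the lower number. Among the compounds shown here, they also leave open whether the same order would hold on a core other than the one that all three compounds share.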